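This account rests on a few compounds, and the source may have more. Where it says the series, first, only, none or still open, it means among the compounds named here.

Compound 1, `CC1CCN(C(=O)c2c(N)sc(-c3ccc(Cl)cc3)c2-c2ccc(Cl)cc2)CC1`: 5750 nM
Compound 2, `CS(=O)(=O)Nc1sc(-c2ccc(Cl)cc2)c(-c2ccc(Cl)cc2)c1C(=O)NC1CC1`: "not determined" (no result reported)

Among the compounds with values here, in a functional assay on PC-3 cells (Homo sapiens) for inhibition, read by sulforhodamine B assay, with a stated time of 72 h (on this read-out lower numbers stand for stronger inhibition and higher numbers for weaker inhibition), compound 1 gives 5750 nM, the only number in hand. For compound 2 the outcome in this assay is "not determined" (no result reported), so it offers no comparison. Compound 3, `Nc1sc(-c2ccc(Cl)cc2)c(-c2ccc(Cl)cc2)c1C(=O)NC1CC1`, keeps the shared core of compound 1 and differs from it by cyclopropylamino in place of 4-methylpiperidin-1-yl on a carbonyl carbon. Within the data shown here, no two measured compounds differ in one place, so no measured step exists to lean on. The step expected from compound 1 to compound 3 is a 1.3-fold lower number from compound 1 to compound 3 (0.11 log units; within the scatter), no larger than the usual scatter and open in direction. Compound 3 is expected to give about 4500 nM, within 1200 nM to 16000 nM.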

Compound 3, half-maximal inhibitory concentration: 3680 nM
The estimate for compound 3 lay 1.2-fold (0.09 log units) above the measured number; the measured number falls inside the stated range.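

In this assay, placing cyclopropylamino in place of 4-methylpiperidin-1-yl on a carbonyl carbon gives a 1.6-fold lower number from compound 1 to compound 3 (0.19 log units; within the scatter). At this position, then, a six-membered ring can give way to a three-membered ring, with a hydrogen-bond donor entering, without a change that stands out from the scatter. No measurement on hand offers an explanation for this. From the compounds shown here alone, whether a longer chain such as n-butylamino, or a group carrying a carboxylic acid, would move the number at this carbonyl stays open. Compound 2 gives no result, so nothing can be read from it.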